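The compounds below may be only part of what the source reports. "The series", "measured", "known", "first", "only" and "open" are said of these compounds alone.

Measured compounds:
- compound 1 `Cc1cccc(/C(N)=N/NC(=S)N2CCCCC2)n1`: 74000 nM
- compound 2 `N/C(=N\NC(=S)N1CCN(c2ccccn2)CC1)c1ccccn1`: 13700 nM
- compound 3 `N/C(=N\NC(=S)N1CCCCC1)c1ccccn1`: 8500 nM

In a functional assay on MCF7 cells (Homo sapiens) for cytotoxicity, read by MTT assay, with a stated time of 72 h (on this read-out higher numbers stand for weaker inhibition and lower numbers for stronger inhibition), compound 1 gives the highest number of the three. Compound 2 and compound 3 sit lower, and the step of an 8.7-fold lower number from compound 1 to compound 3 (0.94 log units; beyond the scatter) is the only one that can be fully traced. Compound 4 `Cc1cccc(/C(N)=N/NC(=S)N2CCSCC2)n1` has not been tested; it differs from compound 1 in one place: thiomorpholin-4-yl in place of piperidin-1-yl on a thiocarbonyl carbon. Among the measured compounds shown here, no measured pair changes the ring on the thiocarbonyl carbon alone, so the relevant evidence is thin; compound 2 and compound 3 show that a different ring there coincides with a moderate difference in this assay. A step no larger than the scatter is therefore expected, a 1.2-fold lower number from compound 1 to compound 4 (0.09 log units; within the scatter). Compound 4 is estimated at 60000 nM, between 25000 nM and 150000 nM.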

Compound 4, half-maximal inhibitory concentration: > 100000 nM
Compound 4 gave a limit, no number (the forecaster's own chance of this, stated with the estimate: 10%); middle value at least 1.6-fold (0.22 log units) away from the limit.
By their numbers in this assay, from the lowest: compounds 3 and 2 (each within the scatter of the next); then compound 1. At a limit, above all of these: compound 4.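

Among the compounds shown here, for the first time, the ring on the thiocarbonyl carbon is changed alone: in this assay, thiomorpholin-4-yl in place of piperidin-1-yl gives an at least 1.3-fold higher number from compound 1 to compound 4 (0.13 log units; that floor lies within the scatter). Compound 4 gives a limit of the assay and not a number: the limit of > 100000 nM in this assay, at which 1 of the 4 values shown sits. From the compounds shown here alone, the change therefore brings no lower number on the core of compound 1, but the true size of the step stays unknown.

Going by these compounds, it remains open whether thiomorpholin-4-yl would act alike on the core of compound 3, which lacks the methyl. Also open, on these data alone, is what a morpholin-4-yl ring or an open-chain dimethylamino group would give on the thiocarbonyl carbon.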